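Fibroblast cytotoxicity: methylating one hydroxy of compound 2

The source may report more compounds than this note shows. Statements on the series, on what has been measured and on what is new or still open speak of the compounds shown alone.

Measured so far:
compound 1 `COc1cc(NC(C)=O)cc(C(=O)OC/C=C(C)/C=C/C=C(C)/C=C/C2=CCCCC2(C)C)c1O` — < 10000 nM, which is a limit of the assay and not a number
compound 2 `CC(/C=C/C1=CCCCC1(C)C)=C\C=C\C(C)=C\COC(=O)c1c(O)cccc1O` — 14000 nM
compound 3 `CC(/C=C/C1=CCCCC1(C)C)=C\C=C\C(C)=C\COC(=O)c1ccc(O)cc1O` — 120000 nM

In a toxicity assay on cells (Fibroblast, Homo sapiens) for cytotoxicity (on this read-out lower numbers stand for stronger inhibition and higher numbers for weaker inhibition), compound 2 holds the lowest of the two numbers. Its nearest neighbour is compound 3, with an 8.6-fold higher number from compound 2 to compound 3 (0.93 log units; beyond the scatter); that step is beyond the scatter. Compound 1 sits at the limit of < 10000 nM in this assay, at which 1 of the 3 values shown sits, so it gives no number to compare with.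

Compound 4 `COc1cccc(O)c1C(=O)OC/C=C(C)/C=C/C=C(C)/C=C/C1=CCCCC1(C)C` is the next member: methyl in place of hydrogen on an oxygen on an aromatic ring. For the measured compounds named here, the only measured step, from compound 2 to compound 3, changes where the second hydroxy sits rather than capping one, so it bears on this change only loosely. Going by the values given here, no step covers methylation of a hydroxy. A step within the scatter, or a small move toward a higher number, is the expectation for this assay.

For compound 4 in this assay the estimate is 22000 nM, with a range from 8000 nM to 60000 nM; this implies an expected 1.6-fold higher number from compound 2 to compound 4 (0.20 log units; within the scatter).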

Compound 4, half-maximal inhibitory concentration: 230000 nM
The estimate for compound 4 lay 10-fold (1.02 log units) below the measured number, and the stated range ends below it.
By their numbers in this assay, from the lowest: compound 2; then compounds 3 and 4 (each within the scatter of the next). At a limit, below all of these: compound 1.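

In this assay, hydroxy to methoxy on the 2,6-dihydroxyphenyl group is a large change, giving a 16-fold higher number from compound 2 to compound 4 (1.22 log units; beyond the scatter), so this hydroxy counts for much more than a single added methyl might suggest. Compound 2 now stands apart from the other two compounds with numbers, and those two are not separated from each other: a 1.9-fold higher number from compound 3 to compound 4 (0.28 log units; within the scatter). For the compounds shown here, nothing measured here bears on why capping this hydroxy moves the number so far.

On these data alone, it remains open whether an amine or an ethoxy in that place would stay with compound 2 or with compound 4. Compound 1 gives < 10000 nM, a limit and not a number, so its steps to the other compounds cannot be read.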